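The source may hold more compounds than are shown below. What is called first, only, known or untested is meant among the compounds shown, and "the series" means these compounds.

Compound 1 `O=C1O/C(=C\Cn2cc(-c3ccc(Br)cc3)nn2)C(OCc2ccccc2)=C1OCc1ccccc1` joins the shared core to its side chain through a double bond. In a functional assay on SW-620 cells (Homo sapiens) for antiproliferative activity, read by MTT assay, with a stated time of 72 h (a higher number here means a weaker inhibitor, a lower number a stronger inhibitor), compound 1 gives only a limit of the assay, > 100000 nM. Compound 2 `O=C1O[C@H]([C@@H](O)Cn2cc(-c3ccc(Br)cc3)nn2)C(OCc2ccccc2)=C1OCc1ccccc1` replaces that double bond with a saturated link bearing a hydroxyl, and in this assay compound 2 gives 3760 nM. Compound 3 `CCCCCc1ccc(-c2cn(C[C@H](O)[C@H]3OC(=O)C(OCc4ccccc4)=C3OCc3ccccc3)nn2)cc1` differs from compound 2 only on the aromatic ring that carries the bromo group, and in this assay compound 3 gives 12200 nM. Compound 4 `COc1ccc(-c2cn(C/C=C3\OC(=O)C(OCc4ccccc4)=C3OCc3ccccc3)nn2)cc1` is compound 1 with methoxy in place of bromo on an aromatic carbon. Among the compounds with values here, the one measured change at that aromatic position, a 3.2-fold higher number from compound 2 to compound 3 (0.51 log units; beyond the scatter), was modest, and it was seen on the hydroxy compounds rather than on the double-bond compound 1, which sits at the limit (the limit of > 100000 nM in this assay, at which 1 of the 3 values shown sits). A shift of similar size, starting from a limit, is expected to leave compound 4 near that limit, which is a step that the limit leaves unreadable from compound 1 to compound 4. Compound 4 is therefore estimated at 120000 nM, with a range from 20000 nM to 600000 nM.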

Compound 4, half-maximal inhibitory concentration: > 100000 nM
Compound 4 ended at the assay's limit (the forecaster's own chance of this, stated with the estimate: 70%); the middle value is on the limit's open side.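

Compound 1 and compound 4 both sit at a limit of the assay rather than at a readable number, so no size can be given for the change from bromo to methoxy: the limit of > 100000 nM in this assay, at which 2 of the 4 values shown sit.

The compounds shown leave open how methoxy in place of bromo acts in this assay when both values are readable.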